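Replacing a Methoxycarbonyl Group with Benzyl: Expected Stability

A few compounds are considered here, and "the series" means these few. Any claim that something is new, unique, unknown or untested is made for them only; others in the source may bear on it.

Of the compounds shown here, three built on one shared core have been tested in an ADME assay on microsomes from liver (Rattus norvegicus) for metabolic stability, with a stated time of 10 min; a higher number here means that more of the compound is left, a lower number that less of the compound is left. Compound 1 `CC(C)OC(=O)NCCS(=O)(=O)NC(=O)c1ccc(Nc2nc(NC3(c4ccc(Cl)cc4)CC3)nc(OCC(F)(F)F)n2)cc1` gives 73%. Compound 2 `CC(C)S(=O)(=O)NC(=O)c1ccc(Nc2nc(NC3(c4ccc(Cl)cc4)CC3)nc(OCC(F)(F)F)n2)cc1` gives 96%, and compound 3 `COC(=O)NCCS(=O)(=O)NC(=O)c1ccc(Nc2nc(NC3(c4ccc(Cl)cc4)CC3)nc(OCC(F)(F)F)n2)cc1` gives 100%. Compound 3 thus shows the largest number of the three, but its difference from compound 2 is only a number 4 percentage points higher from compound 2 to compound 3 (within the scatter), within the scatter, so these two cannot be told apart; only the gap a number 27 percentage points higher from compound 1 to compound 3 (beyond the scatter) lies beyond the scatter.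

Compound 4 `O=C(NS(=O)(=O)CCNCc1ccccc1)c1ccc(Nc2nc(NC3(c4ccc(Cl)cc4)CC3)nc(OCC(F)(F)F)n2)cc1` differs from compound 3 in a single place: benzyl in place of methoxycarbonyl on an amine nitrogen. Within the data shown here, no measured step covers this kind of exchange directly. The step of a number 4 percentage points higher from compound 2 to compound 3 (within the scatter) shows that swapping the whole group on the sulfonyl sulfur for the chain carrying the methoxycarbonyl amino group left this assay essentially unchanged, while a number 27 percentage points higher from compound 1 to compound 3 (beyond the scatter) shows that exchanging isopropyl for methyl on the oxygen moved it by a modest amount. Removing the methoxycarbonyl group altogether and putting a benzyl group in its place is a larger alteration than either, so a modest drop in this assay is expected, with wide uncertainty. Compound 4 is therefore estimated at 72%, within a range from 40% to 98%, which corresponds to an expected step of a number 28 percentage points lower from compound 3 to compound 4 (beyond the scatter).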

Compound 4, percent of the compound remaining: 100%
Compound 4: the middle estimate sits 28 percentage points below what was measured; the whole stated range lies below it.
By their numbers in this assay, from the lowest: compound 1; then compounds 2, 3 and 4 (each within the scatter of the next).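

In this assay, the amine nitrogen on the chain accepts a very different group: benzyl, with 7 heavy atoms and a six-membered aromatic ring, replaces methoxycarbonyl, with 4 heavy atoms including 2 oxygens, and the result is no change at the digits printed from compound 3 to compound 4 (within the scatter). The earlier compounds shown here all carried a carbonyl group on this nitrogen, whereas compound 4 has none, and the comparison with the short isopropyl group on the sulfonyl sulfur also stays level, at a number 4 percentage points higher from compound 2 to compound 4 (within the scatter). Among the three groups now seen on this nitrogen, only isopropoxycarbonyl stands apart, as a number 27 percentage points higher from compound 1 to compound 4 (beyond the scatter) shows.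

The compounds shown leave open what happens with the bare amine, with hydrogen in place of benzyl, or with a longer chain such as 2-phenylethyl, and whether a chlorine or a carboxylic acid on the benzyl ring would keep the number at this level. Nothing measured here accounts for why benzyl and methoxycarbonyl give the same number in this read-out.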